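Swapping Fluoro for Chloro on a Scaffold at the Limit

The source may report more compounds than this note shows. Statements on the series, on what has been measured and on what is new or still open speak of the compounds shown alone.

Compound 2 `N#CC1=C(N)Oc2c(N)cc3nc4ccccc4nc3c2C12C(=O)N(Cc1cnnn1-c1ccc(F)cc1)c1ccccc12` carries a 4-fluorophenyl group on an aromatic nitrogen. In an ADME assay on HUVEC cells (Homo sapiens) for antiproliferative activity, read by MTT assay, with a stated time of 48 h (a lower number here means a stronger inhibitor, a higher number a weaker inhibitor), compound 2 gives > 50000 nM, which is a limit of the assay rather than a number. Compound 1 `CCc1ccccc1-n1nncc1CN1C(=O)C2(C(C#N)=C(N)Oc3c(N)cc4nc5ccccc5nc4c32)c2ccccc21` also reaches only a limit: in this assay compound 1 gives > 50000 nM. The step that the two limits leave unreadable from compound 1 to compound 2 therefore cannot be read. Compound 3 `N#CC1=C(N)Oc2c(N)cc3nc4ccccc4nc3c2C12C(=O)N(Cc1cnnn1-c1ccc(Cl)cc1)c1ccccc12` differs from compound 2 by chloro in place of fluoro on an aromatic carbon. Going by the values given here, because of the limit of > 50000 nM in this assay, at which 2 of the 2 values shown sit, no measured step bears on this change, and compound 3 is expected to stay at the limit. The estimate for compound 3 is 60000 nM, ranging from 20000 nM to 200000 nM, with the expected step that the limit leaves unreadable from compound 2 to compound 3 none beyond the scatter.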

Compound 3, half-maximal inhibitory concentration: > 50000 nM
Compound 3: only a limit was reported; the forecaster's own chance of this, stated with the estimate: 85%; the middle value lies beyond the limit too.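

Going by these compounds alone, the results for compound 1, compound 2 and compound 3 are all limits, and no step between them can be read. On these data alone, how strongly any of the three acts, and whether chloro and fluoro differ, stays open.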